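A few compounds are considered here, and "the series" means these few. Any claim that something is new, unique, unknown or untested is made for them only; others in the source may bear on it.

In an ADME assay on THP-1 cells (Homo sapiens) for cytotoxicity, read by flow cytometry and propidium iodide staining, with a stated time of 72 h (on this read-out lower numbers stand for stronger inhibition and higher numbers for weaker inhibition), compound 1 (`Nc1ccc2oc(-c3cccc(C(F)(F)F)c3)cc(=O)c2c1`) gives 34000 nM, compound 2 (`COc1c(-c2ccccc2)oc2ccc(N)cc2c1=O`) gives 74000 nM and compound 3 (`COc1cccc(-c2oc3ccc(N)cc3c(=O)c2OC)c1`) gives 37000 nM. Within the data shown here, these are the only numbers available so far. The value of compound 3 lies within the usual scatter of repeated measurements from both other values, so it cannot be ranked against either of them.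

Compound 4 (`COc1c(-c2cccc(C(F)(F)F)c2)oc2ccc(N)cc2c1=O`) has not yet been measured. It differs from compound 3 as follows: trifluoromethyl in place of methoxy on an aromatic carbon. In words, this is trifluoromethyl in place of methoxy on an aromatic carbon, meta to a large group.

Two pieces of evidence bear on this change. Among the measured compounds shown here, the only measured step that involves the methoxy group on an aromatic carbon is a 2.0-fold lower number from compound 2 to compound 3 (0.30 log units; within the scatter), and it stays within the scatter. Compound 1 also carries a trifluoromethyl group and gives 34000 nM, although it lacks the methoxy group that compound 4 keeps on the shared core. No direct comparison of the two groups exists, so neither direction can be favoured, and no step beyond the scatter is expected in this assay.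

The expected size of the change is a 1.1-fold lower number from compound 3 to compound 4 (0.02 log units; within the scatter). Compound 4 is expected to give about 35000 nM, with an estimated range from 16000 nM to 75000 nM.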

Compound 4, half-maximal inhibitory concentration: 33000 nM
The estimate for compound 4 lay 1.1-fold (0.03 log units) above the measured number; measured number inside the range.
By their numbers in this assay, from the lowest: compounds 4, 1, 3 and 2 (each within the scatter of the next, the first and the last beyond it).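

In this assay, among these compounds, trifluoromethyl in place of methoxy gives a 1.1-fold lower number from compound 3 to compound 4 (0.05 log units; within the scatter), the first direct comparison of the two groups on this aromatic carbon, and it does not separate them. Trifluoromethyl in place of hydrogen at the same place gives a 2.2-fold lower number from compound 2 to compound 4 (0.35 log units; beyond the scatter), a modest step and the only one among these compounds that lies beyond the scatter, whereas methoxy in place of hydrogen at that place stays within it. Methoxy in place of hydrogen also now has a second reading, a 1.0-fold lower number from compound 1 to compound 4 (0.01 log units; within the scatter), and the two readings of this change agree within the scatter: the same change on two cores in this assay, a 2.0-fold lower number (0.30 log units; within the scatter) from compound 2 to compound 3 and a 1.0-fold lower number (0.01 log units; within the scatter) from compound 1 to compound 4, 1.9-fold (0.29 log units) apart, within the scatter of two such steps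

Going by these compounds, only hydrogen, methoxy and trifluoromethyl have been compared on this aromatic carbon, so it remains open whether a group such as a nitrile, an amine or a carboxylic acid would give a larger step. On these data alone, it is also open whether the modest step from hydrogen to trifluoromethyl would recur on another core, since it rests on a single pair of compounds.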